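This account rests on a few compounds, and the source may have more. Where it says the series, first, only, none or still open, it means among the compounds named here.

Working notes on the series. Compound 1 `COc1ccc(OCCCCCOc2cccc(NC(N)=S)c2)cc1` has been run in an ADME assay on Ava5 cells (Homo sapiens) for cytotoxicity; on this read-out higher numbers stand for lower toxicity in this test and lower numbers for higher toxicity in this test. In this assay compound 1 returns only the assay limit, > 50000 nM, and not a number. Its standing among the values shown is therefore fixed only in that it sits at the limit of > 50000 nM in this assay, at which 1 of the 3 values shown sits. The two members with numbers are compound 2 `NC(=S)Nc1cccc(OCCCCCOc2ccccc2-c2ccccc2)c1`, which gives 13000 nM in this assay, and compound 3 `NC(=S)Nc1cccc(OCCCCCOc2cccc(C(=O)c3ccccc3)c2)c1`, which gives 13000 nM in this assay; these two values lie within the usual scatter of each other. Going by the values given here, no pair of measured compounds differs in a single place, so no measured step is available.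

Compound 4 `NC(=S)Nc1cccc(OCCCCCOc2ccc(-c3cccs3)cc2)c1` is not yet measured. It differs from compound 1 by thiophen-2-yl in place of methoxy on an aromatic carbon. Among the compounds with values here, with no measured step to go by, the size of the change from compound 1 to compound 4 in this assay can only be gauged from where the other members stand: compound 2 with 13000 nM and compound 3 with 13000 nM both give numbers rather than a limit. The step is expected to go toward higher toxicity, beyond the scatter, at about an at least 3.3-fold lower number from compound 1 to compound 4 (0.52 log units; beyond the scatter). For compound 4 the estimate in this assay is 15000 nM, with a range from 6000 nM to 40000 nM.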

Compound 4, half-maximal cytotoxic concentration: > 50000 nM
Compound 4 was reported as a limit; the forecaster's own chance of this, stated with the estimate: 25%; at least 3.3-fold (0.52 log units) between middle value and limit.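

In this assay compound 1 and compound 4 both return only the assay limit and not a number, so no step can be read between them: the limit of > 50000 nM in this assay, at which 2 of the 4 values shown sit.

The compounds shown leave open how far, if at all, thiophen-2-yl in place of methoxy on an aromatic carbon shifts the half-maximal cytotoxic concentration.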